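Swapping a triazole for an acetamide on a shared core

A few compounds are considered here, and "the series" means these few. Any claim that something is new, unique, unknown or untested is made for them only; others in the source may bear on it.

Of the compounds shown here, two have so far been measured in a functional assay on the whole organism (strain Kunming) with Mus musculus as the target, with a stated time of 30 min; on this read-out lower numbers stand for an effect already at smaller amounts and higher numbers for an effect only at larger amounts of compound. Compound 1 `CCCCCCSc1nnc(COc2ccc(NC(C)=O)cc2)o1` gives 26.8 mg/kg in this assay. Compound 2 `CCCCCSc1nnc(COc2ccc(-n3cnnc3)cc2)o1` gives 27.9 mg/kg in this assay. Among the measured compounds shown here, the two numbers lie within the usual scatter of each other, so neither compound can be called more or less potent than the other; no step between them is worked out, because they differ in more than one place.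

Compound 3 `CCCCCSc1nnc(COc2ccc(NC(C)=O)cc2)o1` is the next compound to be measured in this assay. It carries the same chain as compound 2 and differs from it in one place: acetamido in place of 4H-1,2,4-triazol-4-yl on an aromatic carbon. Compound 3 also shares its acetamido group and its aryl ether linkage with compound 1, with only the chain length set apart.

Since compound 1, which already carries the acetamido group, and compound 2 sit so close together in this assay, a step from compound 2 to compound 3 of no size beyond the scatter is expected, a 1.0-fold lower number from compound 2 to compound 3 (0.01 log units; within the scatter). Compound 3 is therefore estimated at 27 mg/kg, with a range from 14 mg/kg to 54 mg/kg.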

Compound 3, dose for half-maximal effect: 28.1 mg/kg
The estimate for compound 3 lay 1.0-fold (0.02 log units) below the measured number, and the stated range covers the measured number.
By their numbers in this assay, from the lowest: compounds 1, 2 and 3 (each within the scatter of the next).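

Among the compounds shown here, this is the first pair that differs only at the group para to a large group on the six-membered aromatic ring, and in this assay the exchange of a five-membered aromatic ring for acetamido, which has no ring, comes with a 1.0-fold higher number from compound 2 to compound 3 (0.00 log units; within the scatter) and leaves the two compounds indistinguishable. The hydrogen-bond donor that enters with acetamido, and the smaller count of hydrogen-bond acceptors, therefore leave no trace in this read-out at this position, and the saturated chain adds a second reading, since hydrogen in place of methyl at its far end, five bonds along from the sulfur, gives a 1.0-fold higher number from compound 1 to compound 3 (0.02 log units; within the scatter) and so also stays within what repeated measurements would show. Nothing at hand gives a reason why these compounds read so much alike.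

Going by these compounds, both changes were small in this whole-animal test, so it remains open whether this position would tolerate a very different group such as an amine, a carboxylic acid or a halogen in place of acetamido. The same question stands for the chain, where a much longer chain or a branched one could still shift the dose needed, and where only these neighbouring lengths can be compared.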